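A few compounds are considered here, and "the series" means these few. Any claim that something is new, unique, unknown or untested is made for them only; others in the source may bear on it.

Compound 1 `COc1ccc(Nc2c(C#N)c(F)c3c(N)nc(N)nc3c2Cl)cc1`: 103 ug/mL in a functional assay on A549 cells (Homo sapiens) for cytotoxicity, read by MTT assay; on this read-out higher numbers stand for weaker inhibition and lower numbers for stronger inhibition
Compound 2 `N#Cc1c(NCc2ccccc2)c(Cl)c2nc(N)nc(N)c2c1F`: 34.1 ug/mL in this assay

Among the compounds with values here, compound 2 holds the lower of the two numbers in this assay; the single measured step is a 3.0-fold lower number from compound 1 to compound 2 (0.48 log units; beyond the scatter), a modest one. Compound 3 `N#Cc1c(NCc2ccccc2)c(Cl)c2nc(N)nc(N)c2c1NCc1ccccc1` differs from compound 2 by benzylamino in place of fluoro on an aromatic carbon. Within the data shown here, no measured step touches this position or this exchange, so the one known step offers no direct guide, and nothing here argues for a change beyond the scatter. The author therefore expects compound 3 to give about 40 ug/mL in this assay, within 12 ug/mL to 130 ug/mL, which is estimated as a 1.2-fold higher number from compound 2 to compound 3 (0.07 log units; within the scatter).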

Compound 3, half-maximal inhibitory concentration: > 1000 ug/mL
Compound 3 was reported as a limit; the forecaster's own chance of this, stated with the estimate: 10%; middle value at least 25-fold (1.39 log units) away from the limit.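

Exchanging fluoro for benzylamino on the aromatic carbon ortho to a cyano group shifts the read-out strongly towards weaker inhibition in this assay, with an at least 29-fold higher number from compound 2 to compound 3 (1.46 log units; beyond the scatter). This position, which the earlier pair left untouched, therefore proved sensitive to this exchange. Compound 3 stands at a limit of the assay, not at a number: the limit of > 1000 ug/mL in this assay, at which 1 of the 3 values shown sits.

From the compounds shown here alone, whether a simple amine or a methoxy group on this carbon would keep the number near that of compound 2 remains open. Going by these compounds, it is also open whether the shift follows from losing fluoro or from gaining benzylamino.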